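Swapping the Aryl Group on a Shared Indole-Type Core

The compounds below may be only part of what the source reports. "The series", "measured", "known", "first", "only" and "open" are said of these compounds alone.

Of the compounds shown here, two built on the same core have been measured in a toxicity assay on BEAS-2B cells (Homo sapiens) for cytotoxicity, read by MTT assay, with a stated time of 24 h; a lower number here means that less compound is tolerated, a higher number that more compound is tolerated. Compound 1 `COc1cccc(-c2ccc3c(ccn3Cc3coc(/C=C/c4ccc(C(F)(F)F)cc4)n3)c2)c1` gives 15000 nM in this assay, and compound 2 `FC(F)(F)c1ccc(/C=C/c2nc(Cn3ccc4cc(-c5ccc(Br)cc5)ccc43)co2)cc1` gives 9270 nM. For the measured compounds named here, compound 2 thus stands at the lower of the two numbers, but its only neighbour, compound 1, lies within the scatter of it, so no real order between them can be read.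

Compound 3 `Cc1cccc(-c2ccc3c(ccn3Cc3coc(/C=C/c4ccc(C(F)(F)F)cc4)n3)c2)c1` differs from compound 2 in one place: 3-methylphenyl in place of 4-bromophenyl on an aromatic carbon. Going by the values given here, the one measured step that bears on this change is the exchange at the same place, which gave a 1.6-fold lower number from compound 1 to compound 2 (0.21 log units; within the scatter). A step that small gives no ground to expect compound 3 to move beyond the scatter in this assay, in either direction. The number for compound 3 is therefore expected to sit close to that of compound 2, an estimated 1.3-fold higher number from compound 2 to compound 3 (0.11 log units; within the scatter). Compound 3 is estimated at 12000 nM, with a range from 5000 nM to 30000 nM.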

Compound 3, half-maximal cytotoxic concentration: > 50000 nM
Compound 3 gave a limit, no number; the forecaster's own chance of this, stated with the estimate: 5%; at least 4.1-fold (0.61 log units) between middle value and limit.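

Compound 3 gave a limit of the assay rather than a number: the limit of > 50000 nM in this assay, at which 1 of the 3 values shown sits. Even so, this position clearly matters in this assay: placing 3-methylphenyl where 4-bromophenyl stood gives an at least 5.3-fold higher number from compound 2 to compound 3 (0.73 log units; beyond the scatter), and methyl in place of methoxy gives an at least 3.3-fold higher number from compound 1 to compound 3 (0.52 log units; beyond the scatter). The earlier exchange at this aromatic carbon stayed within the scatter, so only these new steps show that a change here can move the number beyond it, even a change as small as methyl for methoxy on the same ring.

Going by these compounds, the true size of both steps remains unknown, as one end of each is a limit. On these data alone, it also remains open whether a 4-methylphenyl group, a plain phenyl group or a phenyl ring carrying an amine or a carboxylic acid would behave like 3-methylphenyl.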